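Removing the methoxy: what to expect for compound 4

The compounds below may be only part of what the source reports. "The series", "measured", "known", "first", "only" and "open" are said of these compounds alone.

In an assay on isolated protein for inhibition of Amine oxidase [flavin-containing] B (Rattus norvegicus) (a lower number here means a stronger inhibitor, a higher number a weaker inhibitor), three compounds have been measured:

compound 1 `CC#CCN(C)Cc1cc2cc(O)ccc2n1C` gives 8800 nM
compound 2 `C#CCNCc1cc2cc(OC)ccc2n1C` gives 4 nM
compound 3 `CC#CCN(C)Cc1cc2cc(OC)ccc2n1C` gives 370 nM

Compound 3 stands second highest of these three numbers. Its two neighbours are set by large steps: a 24-fold lower number from compound 1 to compound 3 (1.38 log units; beyond the scatter) and a 93-fold higher number from compound 2 to compound 3 (1.97 log units; beyond the scatter). Compound 4 `CC#CCN(C)Cc1cc2ccccc2n1C` is the next compound, and it differs from compound 3 in one place: hydrogen in place of methoxy on an aromatic carbon. Among the measured compounds shown here, no measured step removes the methoxy altogether; the only measured change at this position, a 24-fold lower number from compound 1 to compound 3 (1.38 log units; beyond the scatter), was large, which shows that this position matters but not what a bare hydrogen does. The expectation for compound 4 is therefore a moderate weakening, a 2.4-fold higher number from compound 3 to compound 4 (0.39 log units; beyond the scatter), with wide uncertainty. Compound 4 is estimated at 900 nM, in a range from 150 nM to 5000 nM.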

Compound 4, inhibition constant: 30 nM
Beside the measured number, compound 4's estimate is 30-fold (1.48 log units) above it; measured number outside the range, below it.
By their numbers in this assay, from the lowest: compound 2; then compound 4; then compound 3; then compound 1.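

Methoxy is not needed for a low number on this core: putting hydrogen in its place gives a 12-fold lower number from compound 3 to compound 4 (1.09 log units; beyond the scatter). Replacing hydroxy with hydrogen gives a larger change, a 290-fold lower number from compound 1 to compound 4 (2.47 log units; beyond the scatter), so among compounds 1, 3 and 4, both oxygen groups give higher numbers than hydrogen. Nothing available explains this order.

From the compounds shown here alone, it remains open whether a fluorine or a chlorine on this aromatic carbon would behave more like hydrogen or like methoxy. Also open, going by these compounds, is whether removing methoxy would lower the number with the propargylamino group of compound 2, which gives 4 nM.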